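A few compounds are considered here, and "the series" means these few. Any claim that something is new, unique, unknown or untested is made for them only; others in the source may bear on it.

Within the data shown here, in an assay for inhibition of Fatty-acid amide hydrolase 1 (Rattus norvegicus) (a higher number here means a weaker inhibitor, a lower number a stronger inhibitor), compound 2 `O=C(CCc1ccc(COc2ccccc2)cc1)c1ncc(I)o1` gives 4 nM, the lowest of the two numbers so far, although compound 1 `CN(C)C(=O)c1cnc(C(=O)CCc2ccc(COc3ccccc3)cc2)o1` with 6.7 nM sits within the scatter of it. Among the measured compounds shown here, the only measured step, a 1.7-fold lower number from compound 1 to compound 2 (0.22 log units; within the scatter), is small. Compound 3 `O=C(O)c1ccc(-c2cnc(C(=O)CCc3ccc(COc4ccccc4)cc3)o2)nc1` differs from compound 2 by 5-carboxypyridin-2-yl in place of iodo on an aromatic carbon. For the measured compounds named here, no measured step covers this change; the one known step concerns a different swap at the same aromatic carbon and stayed within the scatter, so the expected step in this assay of a 2.0-fold higher number from compound 2 to compound 3 (0.30 log units; within the scatter) carries wide uncertainty. Compound 3 is estimated at 8 nM, with a range from 2 nM to 40 nM.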

Compound 3, inhibition constant: 4.6 nM
Compound 3: the middle estimate sits 1.7-fold (0.24 log units) above what was measured; the measured number falls inside the stated range.
By their numbers in this assay, from the lowest: compounds 2, 3 and 1 (each within the scatter of the next).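

In this assay the swap of a single iodine atom for 5-carboxypyridin-2-yl, nine heavy atoms including a six-membered aromatic ring, gives a 1.2-fold higher number from compound 2 to compound 3 (0.06 log units; within the scatter) at this aromatic carbon next to the ring oxygen. Against dimethylcarbamoyl, the same group gives a 1.5-fold lower number from compound 1 to compound 3 (0.16 log units; within the scatter) as well. Three very different groups at this position, one now far larger than iodo, thus give numbers within the scatter of one another. Nothing available explains this result. Still open, as far as these compounds go, is whether the free carboxylic acid matters, which its methyl ester could test, and whether an amine at this position would fit the same picture.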